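Chain terminus in the pyridinol series: hydroxy to nonyl

The source may report more compounds than this note shows. Statements on the series, on what has been measured and on what is new or still open speak of the compounds shown alone.

Compound 1 `Cc1c(N(C)C)nc(CCCCCCCCCCO)c(O)c1C` is the weaker of the two compounds measured in a functional assay on cells (Lymphocyte, Homo sapiens), read by trypan blue exclusion, with a stated time of 16 h, tested at 0.5 uM; on this read-out higher numbers stand for a stronger effect at the one concentration tested and lower numbers for a weaker effect. In this assay compound 1 gives 28%. The other measured compound, compound 2 `CCCCCCCCCCCCCCCCc1c(C)c(N2CCC2)nc(C)c1O`, carries a long unbranched chain without a terminal hydroxy, and in this assay compound 2 gives 79%, a number far above compound 1 and well beyond the scatter. Among the measured compounds shown here, no single-change pair between measured compounds is available, so the step to compound 3 `CCCCCCCCCCCCCCCCCCCc1nc(N(C)C)c(C)c(C)c1O` rests on this comparison alone. The change from compound 1 to compound 3 is nonyl in place of hydroxy on a saturated chain carbon, ten or more bonds along the chain from an aromatic carbon, which brings the chain of compound 3 close to that of compound 2. An upward step is therefore expected, and the estimate for compound 3 means a step of a number 37 percentage points higher from compound 1 to compound 3 (beyond the scatter), since compound 2 gives 79% in this assay. Compound 3 is estimated at 65%, with a range from 40% to 85%.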

Compound 3, a percentage reported as activity, at one concentration (the size of the read-out at that concentration, not a potency): 38%
For compound 3 the middle estimate is 27 percentage points above the measured one; measured number below the stated range.
By their numbers in this assay, from the lowest: compounds 1 and 3 (each within the scatter of the next); then compound 2.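

In this assay nonyl in place of hydroxy, on a saturated chain carbon, gives a number 10 percentage points higher from compound 1 to compound 3 (within the scatter) on the shared core. At this place the read-out therefore does not separate the two chain ends, although nonyl brings 9 heavy atoms where hydroxy brought 1 and carries no hydrogen-bond donor or acceptor. Nothing measured on the series accounts for this outcome.

Compound 2 differs from compound 1 and compound 3 in more than one place, so its number cannot be read as a step at this chain end. Open, on these data alone, is whether a carboxylic acid or an amine at the chain end, or a shorter chain, would move the read-out beyond the scatter.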